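A few compounds are considered here, and "the series" means these few. Any claim that something is new, unique, unknown or untested is made for them only; others in the source may bear on it.

Two compounds share one core. Compound 1 `NS(=O)(=O)Oc1ccc2c(c1)CN(C(=O)c1cccc(N3CCC(Cc4ccccc4)CC3)c1)CC2` and compound 2 `CCN(Cc1cccc(Br)c1)c1ccc(C(=O)N2CCc3ccc(OS(N)(=O)=O)cc3C2)cc1` were tested in an assay on HEK293 cells for inhibition of Steryl-sulfatase (Homo sapiens), tested at 0.1 uM; a higher number here means a stronger effect of the compound at the concentration tested, a lower number a weaker effect. Compound 1 gives 1.4%, while compound 2 gives 80.2%, the highest of the two numbers, with its nearest neighbour compound 1 lying lower by a gap beyond the usual scatter. Compound 3 `CCN(Cc1ccc(F)cc1)c1ccc(C(=O)N2CCc3ccc(OS(N)(=O)=O)cc3C2)cc1` differs from compound 2 in one place: 4-fluorophenyl in place of 3-bromophenyl on a saturated chain carbon bound to a nitrogen on an aromatic ring. For the measured compounds named here, no measured pair shows this change, so only a modest downward step is expected, estimated as a number 15.2 percentage points lower from compound 2 to compound 3 (beyond the scatter). In this assay compound 3 is expected to give about 65%, within a range from 35% to 85%.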

Compound 3, a percentage reported as inhibition, at one concentration (the size of the read-out at that concentration, not a potency): 69.1%
Beside the measured number, compound 3's estimate is 4.1 percentage points below it; low and high end bracket the measured number.
By their numbers in this assay, from the lowest: compound 1; then compound 3; then compound 2.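

Placing 4-fluorophenyl instead of 3-bromophenyl on this saturated chain carbon gives, in this assay, a number 11.1 percentage points lower from compound 2 to compound 3 (beyond the scatter). This modest step shows that the position tolerates this change of the aromatic ring with part of the effect lost, not all of it. Nothing measured here explains the drop.

The change swaps the halogen and its place on the ring together, leaving their separate contributions unresolved. A 4-bromophenyl or 3-fluorophenyl group would separate the two, and a cyclohexyl ring would test whether this position needs an aromatic ring at all.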